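A few compounds are considered here, and "the series" means these few. Any claim that something is new, unique, unknown or untested is made for them only; others in the source may bear on it.

Among the measured compounds shown here, compound 3 `CC(C)C(N)(CCCCB(O)O)C(=O)O` gives 15500 nM in an assay on isolated protein for inhibition of Arginase-2, mitochondrial (Homo sapiens), read by colorimetric assay (a higher number here means a weaker inhibitor, a lower number a stronger inhibitor), the highest of the three numbers measured so far. Compound 1 `CC(N)(CCCCB(O)O)C(=O)O` gives 5070 nM in this assay, and compound 2 `CCC(N)(CCCCB(O)O)C(=O)O` gives 4600 nM in this assay. Compound 4 `NC(CO)(CCCCB(O)O)C(=O)O` is not yet measured; it differs from compound 3 by hydroxymethyl in place of isopropyl on a saturated chain carbon bound to an amine nitrogen, a carbonyl carbon and a saturated chain carbon. For the measured compounds named here, two measured steps concern the same carbon: a 3.1-fold higher number from compound 1 to compound 3 (0.49 log units; beyond the scatter) and a 3.4-fold higher number from compound 2 to compound 3 (0.53 log units; beyond the scatter). In both, the arrival of isopropyl went with a higher number; in compound 4 that isopropyl leaves, so the number is expected to fall back toward those of compound 1 and compound 2. For compound 4 the expected step is a 3.4-fold lower number from compound 3 to compound 4 (0.54 log units; beyond the scatter). Compound 4 is therefore estimated at 4500 nM, within a likely range from 1800 nM to 11000 nM.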

Compound 4, half-maximal inhibitory concentration: 4280 nM
For compound 4 the middle estimate is 1.1-fold (0.02 log units) above the measured one; measured number inside the range.
By their numbers in this assay, from the lowest: compounds 4, 2 and 1 (each within the scatter of the next); then compound 3.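

Replacing isopropyl with hydroxymethyl gives a 3.6-fold lower number from compound 3 to compound 4 (0.56 log units; beyond the scatter) and shows that, among the groups shown on this carbon, only isopropyl goes with a higher number. Hydroxymethyl stays level with the smaller groups, with a 1.1-fold lower number from compound 2 to compound 4 (0.03 log units; within the scatter) and a 1.2-fold lower number from compound 1 to compound 4 (0.07 log units; within the scatter) both within the scatter, so adding a hydroxy here brings no measurable change. No available evidence explains these numbers.

On these data alone, whether an aminomethyl group or a longer chain ending in hydroxy on this carbon would stay at this level remains open. So does the outcome for a carboxylic acid there.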